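Triazolylthio to Hydroxy on Two Acetal-Protected Sugar Cores

The source may report more compounds than this note shows. Statements on the series, on what has been measured and on what is new or still open speak of the compounds shown alone.

Measured compounds:
compound 1 `O=[N+]([O-])c1ccc(-c2nc(CO[C@@H]3O[C@H](CO)[C@H]4OC5(CCCC5)O[C@@H]34)no2)cc1`, 41000 nM
compound 2 `CC1(C)O[C@H]2[C@H](OCc3noc(-c4ccc([N+](=O)[O-])cc4)n3)O[C@H](CSc3ncn[nH]3)[C@H]2O1`, > 100000 nM
compound 3 `O=[N+]([O-])c1ccc(-c2nc(CO[C@@H]3O[C@H](CSc4ncn[nH]4)[C@H]4OC5(CCCC5)O[C@@H]34)no2)cc1`, 20000 nM

Of the compounds shown here, three have been tested in a functional assay on WiDr cells (Homo sapiens) for antiproliferative activity, read by sulforhodamine B assay, with a stated time of 48 h; a lower number here means a stronger inhibitor of growth, a higher number a weaker inhibitor of growth. Compound 3 gives 20000 nM. Compound 1, in which the change hydroxy in place of (1H-1,2,4-triazol-5-yl)sulfanyl on a saturated chain carbon bound to a saturated ring carbon has been made, gives 41000 nM, so that the step of a 2.1-fold higher number from compound 3 to compound 1 (0.31 log units; beyond the scatter) weakens growth inhibition by a modest but real amount.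

Compound 2 is known only as a limit, > 100000 nM, which is the boundary of this assay rather than a number; this is the limit (the limit of > 100000 nM in this assay, at which 1 of the 3 values shown sits). The difference between the core of compound 2 and the core of compound 3 is not broken down here.

The unmeasured compound 4 `CC1(C)O[C@H]2[C@H](OCc3noc(-c4ccc([N+](=O)[O-])cc4)n3)O[C@H](CO)[C@H]2O1` arises from compound 2 by hydroxy in place of (1H-1,2,4-triazol-5-yl)sulfanyl on a saturated chain carbon bound to a saturated ring carbon. This is the same change as that between compound 3 and compound 1, at the same place. Going by the values given here, on the measured pair that change gave a 2.1-fold higher number from compound 3 to compound 1 (0.31 log units; beyond the scatter), and the expectation is that the step from compound 2 to compound 4 lies in the same direction and of similar size, a step that the limit leaves unreadable from compound 2 to compound 4, because the only measured instance of this change is a 2.1-fold higher number from compound 3 to compound 1 (0.31 log units; beyond the scatter). Since compound 2 already sits at the limit, compound 4 is estimated to return 200000 nM, between 80000 nM and 600000 nM, and most probably only a limit again.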

Compound 4, concentration for 50% growth inhibition: > 100000 nM
Compound 4: a limit, no number; the forecaster's own chance of this, stated with the estimate: 85%; the middle value is on the limit's open side.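

Compound 4 gives > 100000 nM, which is a limit of the assay and not a number. Going by these compounds alone, compound 2 also stands only as a limit, so no step from compound 2 to compound 4 can be read: the limit of > 100000 nM in this assay, at which 2 of the 4 values shown sit. The compounds shown leave open whether hydroxy in place of (1H-1,2,4-triazol-5-yl)sulfanyl changes growth inhibition on the core of compound 2 as it does from compound 3 to compound 1.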